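The source may hold more compounds than are shown below. What is called first, only, known or untested is meant among the compounds shown, and "the series" means these compounds.

In a functional assay on A549 cells (Homo sapiens) for antiproliferative activity, read by MTT assay, with a stated time of 72 h (on this read-out lower numbers stand for stronger inhibition and higher numbers for weaker inhibition), compound 1 `C=CC(=O)Nc1cccc(Oc2nc(Nc3cccc(C#N)c3)nc3c2CSCC3)c1` gives 6860 nM, the second highest of the three numbers recorded here. Compound 2 `CCC/C=C/C(=O)Nc1cccc(Oc2nc(Nc3cccc(C#N)c3)nc3c2CSCC3)c1` gives 5790 nM and compound 3 `CC(C)/C=C/C(=O)Nc1cccc(Oc2nc(Nc3cccc(C#N)c3)nc3c2CSCC3)c1` gives 35900 nM. The measured steps, a 1.2-fold lower number from compound 1 to compound 2 (0.07 log units; within the scatter) and a 5.2-fold higher number from compound 1 to compound 3 (0.72 log units; beyond the scatter), all concern the chain on the carbonyl carbon, which compound 4 `C=CC(=O)Nc1cccc(Oc2nc(Nc3ccc(OC)nc3)nc3c2CSCC3)c1` keeps unchanged. Compound 4 instead differs from compound 1 at another place: 6-methoxypyridin-3-yl in place of 3-cyanophenyl on a nitrogen on an aromatic ring. Going by the values given here, no measured step touches a nitrogen on an aromatic ring, so the data offer no direct guide, and the change is expected to give no step beyond the usual scatter in this assay, with the range widened for that uncertainty. Compound 4 is therefore estimated at 7000 nM, between 2500 nM and 20000 nM, an expected step of a 1.0-fold higher number from compound 1 to compound 4 (0.01 log units; within the scatter).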

Compound 4, half-maximal inhibitory concentration: 14600 nM
Beside the measured number, compound 4's estimate is 2.1-fold (0.32 log units) below it, and the stated range covers the measured number.
By their numbers in this assay, from the lowest: compounds 2 and 1 (each within the scatter of the next); then compound 4; then compound 3.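

In this assay, going by these compounds alone, the earlier compounds varied only the chain on the carbonyl carbon, and this result shows that the group on the nitrogen on an aromatic ring also affects the read-out. Replacing 3-cyanophenyl with 6-methoxypyridin-3-yl gives a 2.1-fold higher number from compound 1 to compound 4 (0.33 log units; beyond the scatter), a modest weakening. Nothing available explains this step.

As far as these compounds go, the change swaps the nitrile, methoxy group and ring nitrogen together, so their separate contributions remain open. From the compounds shown here alone, it is also open how an unsubstituted phenyl or a pyridin-3-yl group would fare at this place.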